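The source may hold more compounds than are shown below. What is called first, only, known or untested is meant among the compounds shown, and "the series" means these compounds.

Measured so far in a physicochemical assay for solubility, in phosphate buffer, at pH 7.4; a lower number here means a less soluble compound, a higher number a more soluble compound

- Compound 1 `OC1CCN(c2nccnc2OC2CN(c3ccc4ccccc4n3)C2)CC1` gives 99000 nM
- Compound 2 `NC(=O)C1CCN(c2nccnc2OC2CN(c3ccc4ccccc4n3)C2)CC1` gives 14000 nM
- Compound 3 `c1ccc2nc(N3CC(Oc4nccnc4-c4cncnc4)C3)ccc2c1` gives 254000 nM

Compound 3 holds the highest of the three numbers, beyond the scatter of both others. Compound 4 `c1ccc2nc(N3CC(Oc4nccnc4-c4ccc5scnc5c4)C3)ccc2c1` has 1,3-benzothiazol-5-yl in place of pyrimidin-5-yl on an aromatic carbon. For the measured compounds named here, two measured steps concern this place, the modest 2.6-fold higher number from compound 1 to compound 3 (0.41 log units; beyond the scatter) and the large 18-fold higher number from compound 2 to compound 3 (1.26 log units; beyond the scatter). Neither brings in 1,3-benzothiazol-5-yl, so the evidence is indirect. The step at the saturated ring carbon, a 7.1-fold lower number from compound 1 to compound 2 (0.85 log units; beyond the scatter), bears on it less. Both other substituents at this place stand lower than pyrimidin-5-yl, so a large step to a lower number is expected in this assay. The expected change is a 42-fold lower number from compound 3 to compound 4 (1.63 log units; beyond the scatter). The estimate for compound 4 is 6000 nM, with an expected range of 800 nM to 45000 nM.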

Compound 4, solubility: < 1000 nM
Compound 4: a limit, no number; the forecaster's own chance of this, stated with the estimate: 10%; at least 6.0-fold (0.77 log units) between middle value and limit.
By their numbers in this assay, from the lowest: compound 2; then compound 1; then compound 3. At a limit, below all of these: compound 4.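

In this assay compound 4 stands at a limit, not a number: the limit of < 1000 nM in this assay, at which 1 of the 4 values shown sits.

Aromatic character alone does not keep the number high at this position: 1,3-benzothiazol-5-yl falls far short of pyrimidin-5-yl (an at least 250-fold lower number from compound 3 to compound 4 (2.40 log units; beyond the scatter)). It also falls short of both saturated groups, 4-hydroxypiperidin-1-yl (an at least 99-fold lower number from compound 1 to compound 4 (1.99 log units; beyond the scatter)) and 4-carbamoylpiperidin-1-yl (an at least 14-fold lower number from compound 2 to compound 4 (1.14 log units; beyond the scatter)), so the earlier order of pyrimidin-5-yl over those groups does not extend to every aromatic group.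

Going by these compounds, the true size of these steps remains open. So does the standing of 1,3-benzothiazol-5-yl carrying an amine or a carboxylic acid.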